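A few compounds are considered here, and "the series" means these few. Any claim that something is new, unique, unknown or untested is made for them only; others in the source may bear on it.

Measured so far in a functional assay on A549 cells (Homo sapiens) for antiproliferative activity, read by MTT assay, with a stated time of 24 h; on this read-out lower numbers stand for stronger inhibition and higher numbers for weaker inhibition:
Compound 1 `Cc1cccc(-n2cc(-c3cccc(NS(=O)(=O)c4c[nH]c(=O)[nH]c4=O)c3)nn2)c1` gives 3550 nM.
Compound 2 `O=c1[nH]cc(S(=O)(=O)Nc2cccc(-c3cn(-c4cccc(F)c4)nn3)c2)c(=O)[nH]1` gives 7200 nM.
Compound 3 `O=c1[nH]cc(S(=O)(=O)Nc2cccc(-c3cn(-c4ccc(F)cc4)nn3)c2)c(=O)[nH]1` gives > 20000 nM, which is a limit of the assay, not a number.

Compound 3 thus stands at the limit of > 20000 nM in this assay, at which 1 of the 3 values shown sits, with no number of its own. The steps toward it, an at least 5.6-fold higher number from compound 1 to compound 3 (0.75 log units; beyond the scatter) and an at least 2.7-fold higher number from compound 2 to compound 3 (0.44 log units; beyond the scatter), both run toward weaker inhibition, as does a 2.0-fold higher number from compound 1 to compound 2 (0.31 log units; beyond the scatter). Compound 4 `O=c1[nH]cc(S(=O)(=O)Nc2cccc(-c3cn(-c4ccc(Cl)cc4)nn3)c2)c(=O)[nH]1` differs from compound 3 by chloro in place of fluoro on an aromatic carbon. Among the compounds with values here, none of the measured steps exchanges fluoro for chloro; they concern methyl against fluoro and the place of the group on the ring, so none bears directly on this change. Since compound 3 already sits at the limit, no step beyond the scatter is expected in this assay, that is a number no higher from compound 3 to compound 4 (the limit leaves the size open). Compound 4 is estimated at 20000 nM, within 7000 nM to 60000 nM, quite possibly again reported only as a limit.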

Compound 4, half-maximal inhibitory concentration: 1730 nM
Compound 4: middle estimate off by 12-fold (1.06 log units), on the high side, outside the stated range (below it).
By their numbers in this assay, from the lowest: compound 4; then compound 1; then compound 2. At a limit, above all of these: compound 3.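

On this ring carbon, swapping a single atom can decide the result: chloro in place of fluoro gives an at least 11-fold lower number from compound 3 to compound 4 (1.06 log units; beyond the scatter). From the compounds shown here alone, the true size of that step stays open, since compound 3 has only a limit and no number of its own: the limit of > 20000 nM in this assay, at which 1 of the 4 values shown sits. The earlier compounds shown here made a group at this place look unfavourable, yet 4-chlorophenyl also gives a 4.2-fold lower number from compound 2 to compound 4 (0.62 log units; beyond the scatter) and a 2.1-fold lower number from compound 1 to compound 4 (0.31 log units; beyond the scatter).

Going by these compounds, what a bromo, a methoxy or an amine would give on this same carbon remains open. So does the effect of chloro at the ring place that holds the methyl in compound 1.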